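Pyridinyl for pyrimidinyl on the piperazine of the anilide series

A few compounds are considered here, and "the series" means these few. Any claim that something is new, unique, unknown or untested is made for them only; others in the source may bear on it.

Two anilides of this series have been measured in an assay on HEK293 cells for displacement of a labelled ligand from D(4) dopamine receptor (Homo sapiens), read by scintillation counting, with a stated time of 90 min; on this read-out higher numbers stand for weaker inhibition and lower numbers for stronger inhibition. Compound 1 `CCc1cccc(NC(=O)CN2CCN(c3ccccn3)CC2)c1` gives 2.23 nM in this assay. Compound 2 `Cc1cccc(NC(=O)CN2CCN(c3ncccn3)CC2)c1` gives 5.66 nM in this assay, the higher of the two numbers; the gap to compound 1 lies beyond the usual scatter, and the two structures differ in two places at once, so no single-change step can be read from them.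

Compound 3 `Cc1cccc(NC(=O)CN2CCN(c3ccccn3)CC2)c1` is not yet measured. It differs from compound 2 in one place: pyridin-2-yl in place of pyrimidin-2-yl on an amine nitrogen in a ring. Compound 3 thus shares the methyl-bearing anilide of compound 2 and the pyridin-2-yl group of compound 1. Within the data shown here, no step of this kind between measured compounds is available. The expectation rests only on the two values shown: compound 3 is expected to fall between them, as a modest step from compound 2 toward lower numbers, a 1.8-fold lower number from compound 2 to compound 3 (0.25 log units; within the scatter), in this assay. Compound 3 is estimated at 3.2 nM in this assay, with a range from 1.2 nM to 8.5 nM.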

Compound 3, inhibition constant: 1.89 nM
Compound 3: the middle estimate sits 1.7-fold (0.23 log units) above what was measured; the measured number falls inside the stated range.
By their numbers in this assay, from the lowest: compounds 3 and 1 (each within the scatter of the next); then compound 2.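

In this assay, among these compounds, with the methyl-bearing anilide held fixed, pyridin-2-yl in place of pyrimidin-2-yl on the amine nitrogen in the ring gives a 3.0-fold lower number from compound 2 to compound 3 (0.48 log units; beyond the scatter), the first single-change reading at this position. On the anilide side, hydrogen in place of methyl on the saturated chain carbon bound to an aromatic carbon gives a 1.2-fold lower number from compound 1 to compound 3 (0.07 log units; within the scatter), so with pyridin-2-yl in place, that change cannot be told from scatter and only the change on the ring nitrogen reads as a real step. Nothing at hand bears on why the aromatic ring with 1 hetero atom gives the lower number here.

The compounds shown leave open whether the same swap gives a step of like size on the anilide of compound 1, and whether the chain change stays within the scatter with pyrimidin-2-yl on the ring nitrogen. Also open, going by these compounds, is how a plain phenyl on that nitrogen, or a longer chain such as propyl on the anilide, would read in this assay.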